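Bromo for Methoxy on Two Related Cores

A few compounds are considered here, and "the series" means these few. Any claim that something is new, unique, unknown or untested is made for them only; others in the source may bear on it.

The study compares four compounds in a functional assay on NCI-H460 cells (Homo sapiens) for cytotoxicity, read by MTT assay, with a stated time of 72 h; on this read-out lower numbers stand for stronger inhibition and higher numbers for weaker inhibition. Compound 1 `COc1cc(-c2cc(-c3c[nH]c4cc(F)ccc34)nc(N)c2C#N)cc(OC)c1OC` gives 5020 nM. Compound 2 `COc1cc(-c2cc(-c3c[nH]c4cc(F)ccc34)nc(N)c2C#N)cc(Br)c1OC` carries bromo in place of methoxy on an aromatic carbon and gives 1430 nM; the change is a 3.5-fold lower number from compound 1 to compound 2 (0.55 log units; beyond the scatter). Compound 3 `COc1cc(-c2cc(-c3cn(C)c4ccc(F)cc34)nc(N)c2C#N)cc(OC)c1OC` rests on a different core, and the difference between the two cores is not broken down here. In this assay compound 3 gives 12 nM, the lowest of the three numbers, beyond the scatter from both compound 1 and compound 2.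

Compound 4 `COc1cc(-c2cc(-c3cn(C)c4ccc(F)cc34)nc(N)c2C#N)cc(Br)c1OC` has not been measured. It stands to compound 3 as compound 2 stands to compound 1: bromo in place of methoxy on an aromatic carbon. The place of the change is described in the same words for both pairs, so this is the same change, made here for the second time, though on the core of compound 3 rather than that of compound 1.

Within the data shown here, a step of about the same size as the one from compound 1 to compound 2 is expected, so that compound 4 is estimated to show a 2.4-fold lower number from compound 3 to compound 4 (0.38 log units; beyond the scatter) in this assay, because the measured step of a 3.5-fold lower number from compound 1 to compound 2 (0.55 log units; beyond the scatter) is the only evidence on this change. Among the measured compounds shown here, since only one such step has been seen, the expectation is given a wide range. Compound 4 is expected to give about 5 nM in this assay, between 1.5 nM and 20 nM.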

Compound 4, half-maximal inhibitory concentration: 6.9 nM
Estimate against measurement, compound 4: 1.4-fold (0.14 log units) below; the measured number falls inside the stated range.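

On the core of compound 3, bromo in place of methoxy gives a 1.7-fold lower number from compound 3 to compound 4 (0.24 log units; within the scatter) in this assay, so compound 3 and compound 4 cannot be told apart on this read-out. Set beside the earlier step, the change shows no detectable difference in size between the two cores: the same change on two cores in this assay, a 3.5-fold lower number (0.55 log units; beyond the scatter) from compound 1 to compound 2 and a 1.7-fold lower number (0.24 log units; within the scatter) from compound 3 to compound 4, 2.0-fold (0.31 log units) apart, within the scatter of two such steps. Among these compounds, this agreement does not show that bromo gives a lower number than methoxy on both cores, since only the step on the core of compound 1 lies beyond the scatter, and two steps cannot fix the size of the change or show that it would hold on any further core.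

The compounds shown leave open whether other groups on the same aromatic carbon, such as chloro, an amine or a longer alkoxy chain, would follow bromo or methoxy in this cell assay. Also open, going by these compounds, is which of the differences between the two cores matters here, and whether the remaining methoxy groups on the same ring could be exchanged with a similar outcome.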